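The source may hold more compounds than are shown below. What is called first, only, known or untested is meant among the compounds shown, and "the series" means these compounds.

Compound 1 `CCCCCn1c(Cc2cc(OC)c(OC)c(OC)c2)nc2c(N)nc(F)nc21`: 286000000 nM
Compound 2 `C=CCCn1c(Cc2cc(OC)c(OC)c(OC)c2)nc2c(N)nc(F)nc21`: 102000000 nM
Compound 3 `COc1cc(Cc2nc3c(N)nc(F)nc3n2CC2CCC2)cc(OC)c1OC`: 109000000 nM

In a functional assay on MCF7 cells (Homo sapiens) for cytotoxicity (a lower number here means that less compound is needed, a higher number that more compound is needed for the effect), compound 3 stands second highest of the three numbers, close to compound 2 and well apart from compound 1. Compound 4 `COc1cc(Cc2nc3c(N)nc(F)nc3n2CC2CCCO2)cc(OC)c1OC` differs from compound 3 in one place: oxolan-2-yl in place of cyclobutyl on a saturated chain carbon bound to an aromatic nitrogen. Two measured steps end at this same place. The step of a 2.6-fold lower number from compound 1 to compound 3 (0.42 log units; beyond the scatter) was modest, and the step of a 1.1-fold higher number from compound 2 to compound 3 (0.03 log units; within the scatter) stayed within the scatter. Neither step swaps one ring for another, and neither brings in an oxygen, so they give only an indirect guide. With both earlier changes at this place showing little movement, the change from compound 3 to compound 4 is expected to leave this assay roughly unchanged, with no step beyond the scatter. The estimate for compound 4 is 110000000 nM, spanning 40000000 nM to 300000000 nM, an expected step of a 1.0-fold higher number from compound 3 to compound 4 (0.00 log units; within the scatter).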

Compound 4, half-maximal effective concentration: 147000000 nM
Estimate against measurement, compound 4: 1.3-fold (0.13 log units) below; measured number inside the range.
By their numbers in this assay, from the lowest: compounds 2, 3, 4 and 1 (each within the scatter of the next, the first and the last beyond it).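

For the compounds shown here, the oxolan-2-yl group is the first group at this place with an oxygen and a hydrogen-bond acceptor, and in this assay the swap from cyclobutyl gives a 1.3-fold higher number from compound 3 to compound 4 (0.13 log units; within the scatter) and stays within the scatter. The swap from allyl gives a 1.4-fold higher number from compound 2 to compound 4 (0.16 log units; within the scatter) and the swap from butyl gives a 1.9-fold lower number from compound 1 to compound 4 (0.29 log units; within the scatter) and neither leaves the scatter. Nothing measured here gives a reason for these numbers.

The swap from cyclobutyl changes the ring size and adds the oxygen at once, so the two remain unseparated. As far as these compounds go, a cyclopentyl group would separate them, and how an amine at this place would behave stays open.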